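This account rests on a few compounds, and the source may have more. Where it says the series, first, only, none or still open, it means among the compounds named here.

Compound 2 `COc1ccc(-c2cc(C(C)=O)c3[nH]c(-c4ccc(F)cc4)cc3c2)cc1` stands highest of the two numbers in a functional assay on HeLa cells (Homo sapiens) for cytotoxicity, read by MTT assay, with a stated time of 2 days, tested at 100 uM (on this read-out lower numbers stand for a stronger effect and higher numbers for a weaker effect at the one concentration tested), where compound 2 gives 20.6%, while compound 1 `CC(=O)c1cc(-c2ccc(F)cc2)cc2cc(-c3ccc(F)cc3)[nH]c12` gives 9.31%. Among the compounds with values here, the only measured step, a number 11.3 percentage points higher from compound 1 to compound 2 (beyond the scatter), concerns methoxy in place of fluoro on an aromatic carbon. Compound 3 `CC(=O)c1cc(/C=C/c2ccccc2)cc2cc(-c3ccc(F)cc3)[nH]c12` differs from compound 2 by 2-phenylethenyl in place of 4-methoxyphenyl on an aromatic carbon. Within the data shown here, no measured step concerns a change of this kind, so neither size nor direction in this assay can be read from the numbers, and no step beyond the scatter is expected. Compound 3 is estimated to give 15%, between 5% and 35%. The expected step is a number 5.6 percentage points lower from compound 2 to compound 3 (within the scatter).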

Compound 3, a percentage reported as activity, at one concentration (the size of the read-out at that concentration, not a potency): 24.3%
The estimate for compound 3 lay 9.3 percentage points below the measured number, and the stated range covers the measured number.
By their numbers in this assay, from the lowest: compound 1; then compounds 2 and 3 (each within the scatter of the next).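

In this assay, 2-phenylethenyl and 4-methoxyphenyl at this position, meta to an acetyl group, cannot be told apart, with a number 3.7 percentage points higher from compound 2 to compound 3 (within the scatter) and no order between them. The 4-fluorophenyl group of compound 1 stays apart from the 2-phenylethenyl group, with a number 15 percentage points higher from compound 1 to compound 3 (beyond the scatter) as the second step at this position beyond the scatter. No measurement given here explains either result. On these data alone, what an amine or a carboxylic acid at this position would do remains open, as does the effect of a saturated chain in place of the 2-phenylethenyl double bond.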